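This account rests on a few compounds, and the source may have more. Where it says the series, first, only, none or still open, it means among the compounds named here.

Measured so far, in an assay on liver for binding affinity to Alpha-1D adrenergic receptor (Homo sapiens), using microsomes; a higher number here means a weaker inhibitor, a lower number a stronger inhibitor:
- compound 1 `COC(=O)C1=C(C)NC(=O)N(C(=O)NCCCN2CCN(c3ccc(Cl)cc3)CC2)C1c1ccc(F)c(F)c1`: in this assay compound 1 gives 52 nM
- compound 2 `COC(=O)C1=C(C)NC(=O)N(C(=O)NCCCN2CCN(c3cccc(Cl)c3)CC2)C1c1ccc(F)c(F)c1`: in this assay compound 2 gives 37 nM
- compound 3 `COC(=O)C1=C(C)NC(=O)N(C(=O)NCCCN2CCN(c3ccc(OC)cc3C)CC2)C1c1ccc(F)c(F)c1`: in this assay compound 3 gives 610 nM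

Compound 3 has the highest number of the three, so it is the weakest inhibitor shown: the step of a 12-fold higher number from compound 1 to compound 3 (1.07 log units; beyond the scatter) and the step of a 16-fold higher number from compound 2 to compound 3 (1.22 log units; beyond the scatter) are both large and beyond the scatter, while a 1.4-fold lower number from compound 1 to compound 2 (0.15 log units; within the scatter) is within the scatter, so the two chlorophenyl compounds behave alike.

Compound 4 `COC(=O)C1=C(C)NC(=O)N(C(=O)NCCCN2CCN(c3cccc([N+](=O)[O-])c3)CC2)C1c1ccc(F)c(F)c1` differs from compound 3 in one place: 3-nitrophenyl in place of 4-methoxy-2-methylphenyl on an amine nitrogen in a ring. Among the measured compounds shown here, the steps that bear on this are the two that lead into compound 3, since each exchanges the 4-methoxy-2-methylphenyl for a chlorophenyl and both gave a large gain in this assay. For the measured compounds named here, compound 4 carries a single substituent on its phenyl, as compounds 1 and 2 do, so a large step back down is expected, a 7.6-fold lower number from compound 3 to compound 4 (0.88 log units; beyond the scatter), though no measured step shows a nitro group itself. For compound 4 the expected value in this assay is 80 nM, within 25 nM to 250 nM.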

Compound 4, inhibition constant: 340 nM
Compound 4: middle estimate off by 4.3-fold (0.63 log units), on the low side, outside the stated range (above it).
By their numbers in this assay, from the lowest: compounds 2 and 1 (each within the scatter of the next); then compounds 4 and 3 (each within the scatter of the next).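

In this assay, having a single substituent on the phenyl does not by itself give the low numbers of the chlorophenyl compounds: 3-nitrophenyl in place of 4-methoxy-2-methylphenyl gives a 1.8-fold lower number from compound 3 to compound 4 (0.25 log units; within the scatter). Nitro in place of chloro on an aromatic carbon gives a 9.2-fold higher number from compound 2 to compound 4 (0.96 log units; beyond the scatter), and 3-nitrophenyl in place of 4-chlorophenyl gives a 6.5-fold higher number from compound 1 to compound 4 (0.82 log units; beyond the scatter), so the identity of the substituent matters at this place, not just how many substituents the phenyl carries. No measurement at hand explains this difference.

On these data alone, it remains open whether a nitrile or a trifluoromethyl group on the phenyl would stay close to chloro or fall closer to nitro. A 4-nitrophenyl would show whether moving the nitro group around the ring changes the number, as moving the chloro did not.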